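Shortening the benzyl urea of compound 1 to propyl

The source may hold more compounds than are shown below. What is called first, only, known or untested is meant among the compounds shown, and "the series" means these compounds.

Compound 1 `CCN(CC)c1cc2[nH]c(C3CCCCC3)nc2cc1NC(=O)NCc1ccccc1` was run in an ADME assay on Vero cells (Chlorocebus sabaeus) for cytotoxicity, read by resazurin assay, with a stated time of 3 days; on this read-out lower numbers stand for stronger inhibition and higher numbers for weaker inhibition. Compound 1 gives only a limit there, > 100 ug/mL. Compound 2 `O=C(NCc1ccccc1)Nc1cc2nc(C3CCCCC3)[nH]c2cc1N1CCCC1` likewise gives only a limit, > 100 ug/mL. The step that the two limits leave unreadable from compound 1 to compound 2 swaps pyrrolidin-1-yl in place of diethylamino on an aromatic carbon, and the limit of > 100 ug/mL in this assay, at which 2 of the 2 values shown sit, is all the record shows. Compound 3 `CCCNC(=O)Nc1cc2nc(C3CCCCC3)[nH]c2cc1N(CC)CC` differs from compound 1 by ethyl in place of phenyl on a saturated chain carbon bound to an amide-type nitrogen. Going by the values given here, no measured step bears on this change and neither neighbour yields a number, so nothing beyond a limit is expected. Compound 3 is therefore expected to give 150 ug/mL, between 70 ug/mL and 400 ug/mL, meaning a step that the limit leaves unreadable from compound 1 to compound 3.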

Compound 3, half-maximal inhibitory concentration: > 100 ug/mL
Compound 3 gave a limit, no number (the forecaster's own chance of this, stated with the estimate: 85%); the middle value does not contradict the limit.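

No new step can be read from compound 1 to compound 3, since both give only a limit in this assay: the limit of > 100 ug/mL in this assay, at which 3 of the 3 values shown sit. The compounds shown leave open how far each one lies from that limit.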